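Vinyl replacing nitrile on the shared pyrimidine core

The compounds below may be only part of what the source reports. "The series", "measured", "known", "first", "only" and "open" are said of these compounds alone.

The account concerns two measured compounds and one awaiting measurement. In an assay on isolated protein for inhibition of dihydropyrimidine dehydrogenase [NADP(+)] (Homo sapiens) (on this read-out lower numbers stand for stronger inhibition and higher numbers for weaker inhibition), compound 1 `Oc1ncc(/C=C/c2ccccc2)c(O)n1` gives 43 nM. Compound 2 `N#Cc1cnc(O)nc1O` gives 200 nM in this assay, the higher of the two numbers, and the gap to compound 1 lies beyond the scatter. Compound 3 `C=Cc1cnc(O)nc1O` differs from compound 2 by vinyl in place of cyano on an aromatic carbon. Among the compounds with values here, no step between measured compounds is available for this exact change, so the expectation rests on the two values shown. Because compound 1 with its longer chain at the same place gives 43 nM, a modest move toward a lower number is expected, of a size at or a little beyond the scatter. The step from compound 2 to compound 3 is thus expected to be a 2.5-fold lower number from compound 2 to compound 3 (0.40 log units; beyond the scatter). For compound 3 the estimate in this assay is 80 nM, with a range from 20 nM to 300 nM.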

Compound 3, half-maximal inhibitory concentration: 89 nM
The estimate for compound 3 lay 1.1-fold (0.05 log units) below the measured number; measured number inside the range.
By their numbers in this assay, from the lowest: compound 1; then compound 3; then compound 2.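

Vinyl in place of cyano on this aromatic carbon gives a 2.2-fold lower number from compound 2 to compound 3 (0.35 log units; beyond the scatter) in this assay and so supplies the direct step at this position that the earlier compounds lacked. The position accepts the exchange of cyano, with its hydrogen-bond acceptor, for vinyl, with none and the same count of heavy atoms, and the number falls modestly rather than rises, so the acceptor on cyano is not required for a value in this range. Nothing measured here bears on why the step goes this way.

The compounds shown leave open how an amine, a carboxylic acid or a saturated ethyl chain would read on this same aromatic carbon. They also leave open how much of the value of compound 1 at 43 nM depends on the phenyl group at the end of its longer chain.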